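Series notes: a sulfur-free replacement on the shared core

The source may report more compounds than this note shows. Statements on the series, on what has been measured and on what is new or still open speak of the compounds shown alone.

Measured in a functional assay on HEK293 cells for agonist activity at G-protein coupled receptor 39 (Homo sapiens), read by scintillation proximity assay and inositol phosphate accumulation, with a stated time of 75 min, in the presence of a further agent that is not named here; on this read-out lower numbers stand for an effect already at smaller amounts and higher numbers for an effect only at larger amounts of compound:
Compound 1 `Cc1nn(-c2ncnc3nc[nH]c23)c2c1C(C(=O)N(C)c1nccs1)CC(=O)N2`, 18 nM
Compound 2 `CC(C)(C)c1cc(C(=O)N/N=C/c2ccc(O)cc2O)[nH]n1`, 240 nM
Compound 3 `C/C(=N\NC(=O)c1cc2ccccc2cc1O)c1ccc(N)cc1`, 1100 nM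

Compound 1 gives the lowest number of the three. Compound 2 lies well beyond the scatter above it, and compound 3 further still; both gaps are clearly beyond the usual scatter. Going by the values given here, no step between two measured compounds that differ in one place is available, so the effect of any single change on the core of compound 1 has not been observed.

Compound 4 `Cc1nn(-c2ncnc3nc[nH]c23)c2c1C(OCCn1nccc1C)CC(=O)N2` is the next candidate. It differs from compound 1 in one place: a group of 9 heavy atoms (6 carbon, 2 nitrogen, 1 oxygen; one five-membered aromatic ring with 2 hetero atoms) in place of a group of 9 heavy atoms (5 carbon, 2 nitrogen, 1 oxygen, 1 sulfur; one five-membered aromatic ring with 2 hetero atoms), on a saturated ring carbon. The methyl(1,3-thiazol-2-yl)carbamoyl group is lost, and the entering group carries no sulfur and no double bond outside aromatic rings, while keeping the same count of heavy atoms and acceptors. Whether this position tolerates such a change is not shown by any measured pair here.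

A moderate step toward larger amounts is expected, a 2.5-fold higher number from compound 1 to compound 4 (0.40 log units; beyond the scatter), since the series shows that departures from compound 1 have so far given higher numbers, as compound 2 with 240 nM illustrates. Compound 4 is therefore estimated at 45 nM in this assay, with a range from 8 nM to 250 nM.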

Compound 4, half-maximal effective concentration: 10 nM
For compound 4 the middle estimate is 4.5-fold (0.65 log units) above the measured one, within the range that was stated.
By their numbers in this assay, from the lowest: compounds 4 and 1 (each within the scatter of the next); then compound 2; then compound 3.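

In this assay, going by these compounds alone, the exchange gives a 1.8-fold lower number from compound 1 to compound 4 (0.26 log units; within the scatter) and so leaves the two compounds indistinguishable on this read-out, which is the first view of a single change on the shared core. The methyl(1,3-thiazol-2-yl)carbamoyl group on this saturated ring carbon is therefore not required for a number in this range: a group with the same count of heavy atoms, no sulfur and no double bond outside aromatic rings serves equally well in this one pair. Nothing measured here bears on why the two groups give such similar numbers.

The compounds shown leave open how far this tolerance extends, since a single pair cannot say whether a carboxylic acid or an amine on the same saturated ring carbon would also fit. Also open, as far as these compounds go, is whether a longer chain in place of the two-carbon link of the entering group, or another five-membered aromatic ring at its end, would keep the number in the same range.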